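Ester in place of amide on a thiophene dihydropyrimidinone

The source may hold more compounds than are shown below. What is called first, only, known or untested is meant among the compounds shown, and "the series" means these compounds.

Of the compounds shown here, three sharing one core have been tested in an assay on membranes from CHO cells for displacement of a labelled ligand from adenosine receptor A1 (Homo sapiens), read by scintillation counting, with a stated time of 60 min, tested at 1 uM; on this read-out lower numbers stand for less inhibition and higher numbers for more inhibition at the one concentration tested (going by the name of the read-out). Compound 1 `COC(=O)C1=C(C)NC(=O)NC1c1cccs1` gives 6%; compound 2 `CC1=C(C(=O)C2CC2)C(c2cccs2)NC(=O)N1` gives 1%; compound 3 `CCN(CC)C(=O)C1=C(C)NC(=O)NC1c1cccs1` gives 13%. Compound 3 holds the highest of the three numbers, though the gap to compound 1 is within the scatter, as a number 7 percentage points higher from compound 1 to compound 3 (within the scatter) shows, while the gap to compound 2, a number 12 percentage points higher from compound 2 to compound 3 (beyond the scatter), is beyond it and modest.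

Compound 4 `CC1=C(C(=O)OCC2CCC2)C(c2cccs2)NC(=O)N1` has not yet been measured. It differs from compound 3 in one place: cyclobutylmethoxy in place of diethylamino on a carbonyl carbon. The two steps that bear on this change both lead into the diethylamino group from a smaller group on the same carbonyl carbon, a number 7 percentage points higher from compound 1 to compound 3 (within the scatter) and a number 12 percentage points higher from compound 2 to compound 3 (beyond the scatter); neither is large, and the step from the methoxy ester is within the scatter. Compound 4 returns to an oxygen-linked group, so in this assay a small fall is expected, a number 6 percentage points lower from compound 3 to compound 4 (within the scatter), landing near compound 1. Compound 4 is estimated at 7%, expected between -3% and 20%.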

Compound 4, a percentage reported as inhibition, at one concentration (the size of the read-out at that concentration, not a potency): 39%
Beside the measured number, compound 4's estimate is 32 percentage points below it, outside the stated range (above it).
By their numbers in this assay, from the lowest: compounds 2, 1 and 3 (each within the scatter of the next, the first and the last beyond it); then compound 4.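

In this assay, the ester is not what keeps the number low at this position: lengthening methoxy to cyclobutylmethoxy gives a number 33 percentage points higher from compound 1 to compound 4 (beyond the scatter). The same group also clearly outdoes the other two groups on this carbonyl carbon, with a number 26 percentage points higher from compound 3 to compound 4 (beyond the scatter) and a number 38 percentage points higher from compound 2 to compound 4 (beyond the scatter), so the change reaches a level that the small differences among the first three compounds gave no sign of. Nothing measured here explains the rise.

Going by these compounds, it remains open whether the four-membered ring matters or only the added carbons, which an open-chain pentyloxy group or a benzyloxy group on the same carbonyl carbon would help separate. It is also unknown whether the rise would survive an amine at the end of such a chain, and a single percentage at one concentration does not give a potency.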